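The compounds below may be only part of what the source reports. "The series", "measured", "known", "first", "only" and "open" are said of these compounds alone.

Working notes on the series. Compound 1 `CCn1c(C(=O)NCC(=O)OC)ccc1C(CC)(CC)c1ccc(OCS(=O)(=O)c2ccccc2)c(C)c1` is the reference. In a functional assay on PC-3 cells (Homo sapiens) for antiproliferative activity, read by MTT assay, with a stated time of 24 h (on this read-out lower numbers stand for stronger inhibition and higher numbers for weaker inhibition), compound 1 is reported only as a limit, > 50000 nM, so compound 1 stands at the limit of > 50000 nM in this assay, at which 1 of the 2 values shown sits, rather than at a number. Going by the values given here, compound 2 `CCN(CC)CCNC(=O)c1ccc(C(CC)(CC)c2ccc(OCS(=O)(=O)c3ccccc3)c(C)c2)n1CC` differs at the chain on the amide-type nitrogen, and in this assay compound 2 gives 7130 nM; the step is an at least 7.0-fold lower number from compound 1 to compound 2 (0.84 log units; beyond the scatter), the only measured step in the set. Compound 3 `CCn1c(C(=O)N[C@@H](C(=O)O)C(C)C)ccc1C(CC)(CC)c1ccc(OCS(=O)(=O)c2ccccc2)c(C)c1` carries the change (1-carboxy-2-methylpropyl in place of (methoxycarbonyl)methyl on an amide-type nitrogen). The measured step brought in (diethylamino)methyl, whereas compound 3 brings in 1-carboxy-2-methylpropyl, so that step bears on compound 3 only loosely; with compound 1 at a limit, the size of any step cannot be read off. The expectation for compound 3 in this assay is therefore no step beyond the scatter, a step that the limit leaves unreadable from compound 1 to compound 3, with a fair chance of another limit. Compound 3 is estimated at 60000 nM, between 15000 nM and 250000 nM.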

Compound 3, half-maximal inhibitory concentration: 3070 nM
For compound 3 the middle estimate is 20-fold (1.29 log units) above the measured one; measured number outside the range, below it.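

At the amide-type nitrogen in this assay, 1-carboxy-2-methylpropyl in place of (methoxycarbonyl)methyl gives an at least 16-fold lower number from compound 1 to compound 3 (1.21 log units; beyond the scatter). The lower number at this position therefore does not require the diethylamino group of compound 2: the chain of compound 3 carries no amine and still goes further, with a 2.3-fold lower number from compound 2 to compound 3 (0.37 log units; beyond the scatter). Compound 1 is a limit of the assay, so the first of these steps has only a lower bound: the limit of > 50000 nM in this assay, at which 1 of the 3 values shown sits.

On these data alone, whether the step follows the free carboxylic acid, the branched chain or the defined stereocentre stays open, as compound 3 brings in all three together. A carboxymethyl chain on the same nitrogen would separate the carboxylic acid from the branch, and the effect of the opposite stereocentre is also unknown.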